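This account rests on a few compounds, and the source may have more. Where it says the series, first, only, none or still open, it means among the compounds named here.

Compound 1 `CCCCCOC(=O)N1CCN(C(=O)[C@H](CCC(=O)O)NC(=O)c2cc(N3CCC(C(=O)N(CC)CC)CC3)nc(-c3ccccc3)n2)CC1` carries a diethylcarbamoyl group on a saturated ring carbon of the shared core. In an in vivo ADME assay on the whole organism (strain Sprague-Dawley) for pharmacokinetics, with Rattus norvegicus as the target (on this read-out lower numbers stand for slow clearance and higher numbers for fast clearance), compound 1 gives 6 mL/min/kg, the lowest value among the compounds measured here. Compound 2 `CCCCCOC(=O)N1CCN(C(=O)[C@H](CCC(=O)O)NC(=O)c2cc(N3CCC(OCCO)CC3)nc(-c3ccccc3)n2)CC1` gives 18 mL/min/kg, and compound 3 `CCCCCOC(=O)N1CCN(C(=O)[C@H](CCC(=O)O)NC(=O)c2nc(-c3ccccc3)cc(N3CCC(CN)CC3)n2)CC1` gives 16 mL/min/kg.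

Compound 4 `CCCCCOC(=O)N1CCN(C(=O)[C@H](CCC(=O)O)NC(=O)c2cc(N3CCC(C(N)=O)CC3)nc(-c3ccccc3)n2)CC1` differs from compound 1 in one place: amino in place of diethylamino on a carbonyl carbon. Within the data shown here, the one step that bears on this change is the one at the same saturated ring carbon, a 3.0-fold higher number from compound 1 to compound 2 (0.48 log units; beyond the scatter), where the diethylcarbamoyl group was exchanged for 2-hydroxyethoxy. Among the measured compounds shown here, compound 3, which carries aminomethyl in place of the diethylcarbamoyl group on a differently arranged core, also sits higher than compound 1, though no single-point step links the two. Both observations point the same way, so a modest rise is expected in this assay, in the direction of faster clearance, when the diethylamino group is cut back to amino.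

Compound 4 is therefore expected to give about 12 mL/min/kg, with a likely range from 6 mL/min/kg to 25 mL/min/kg, a step of a 2.0-fold higher number from compound 1 to compound 4 (0.30 log units; within the scatter).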

Compound 4, clearance: 68 mL/min/kg
For compound 4 the middle estimate is 5.7-fold (0.75 log units) below the measured one; measured number outside the range, above it.
By their numbers in this assay, from the lowest: compound 1; then compounds 3 and 2 (each within the scatter of the next); then compound 4.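

In this assay, keeping the carbonyl carbon and replacing only diethylamino with amino gives an 11-fold higher number from compound 1 to compound 4 (1.05 log units; beyond the scatter), so the low number of compound 1 does not come from the carbonyl alone and depends on what sits on the amide nitrogen. The exchange of 2-hydroxyethoxy for carbamoyl on the same saturated ring carbon gives a 3.8-fold higher number from compound 2 to compound 4 (0.58 log units; beyond the scatter), which shows that the simple carbamoyl group stands above both of these neighbours rather than between them. Nothing measured here explains why removing the diethylamino group has so large an effect.

Still open, on these data alone, is whether a single ethyl group on the amide nitrogen would sit nearer compound 1 or compound 4. As far as these compounds go, it is equally open where a pyrrolidine ring on the same carbonyl carbon would fall.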